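Second chloro on a fused core: what to expect

This account rests on a few compounds, and the source may have more. Where it says the series, first, only, none or still open, it means among the compounds named here.

Measured compounds:
Compound 1, `ClCc1ccc(Cn2cnc3c(Cl)ncnc32)cc1`, gives "not determined" (no result reported) in a functional assay on SNB-75 cells (Homo sapiens) for cytotoxicity, read by sulforhodamine B assay, with a stated time of 48 h; a higher number here means that more compound is tolerated, a lower number that less compound is tolerated.
Compound 2, `ClCc1ccccc1Cn1cnc2ncnc(Cl)c21`, gives 63100 nM in this assay.

Among the measured compounds shown here, compound 2 stands alone with a number: compound 1 has no result in this assay, so no comparison between measured compounds is possible, and nothing can be said about how any change on this core shifts the read-out.

Compound 3, `ClCc1ccccc1Cn1cnc2nc(Cl)nc(Cl)c21`, is the next compound in line. It differs from compound 2 in one place: chloro in place of hydrogen on an aromatic carbon. In words, compound 3 carries a chloro group where compound 2 carries a hydrogen atom, on the six-membered aromatic ring of the shared core, between two ring nitrogen atoms.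

For the measured compounds named here, since no step between measured compounds exists, the expected step from compound 2 to compound 3 in this assay is taken to be small, at most within or just beyond the usual scatter, and if anything toward less compound tolerated, giving a 1.6-fold lower number from compound 2 to compound 3 (0.20 log units; within the scatter). Compound 3 is therefore expected to come out near 40000 nM, within a range from 10000 nM to 160000 nM.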

Compound 3, concentration lethal to 50% of the cells: > 100000 nM
Compound 3: a limit, no number (the forecaster's own chance of this, stated with the estimate: 20%); middle value at least 2.5-fold (0.39 log units) away from the limit.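

In this assay compound 3 gives > 100000 nM, which is a limit and not a number. Among the compounds shown here, the step can therefore be given only as a floor, an at least 1.5-fold higher number from compound 2 to compound 3 (0.19 log units; that floor lies within the scatter), but it is the first reading of any change on the shared core: chloro in place of hydrogen on this aromatic carbon, between two ring nitrogen atoms, did not bring the number down. Whether the change truly raises the number cannot be decided from a floor of this size, as the real step could be much larger or could vanish into the scatter, and the reading for compound 3 sits at the edge of what the assay reports: the limit of > 100000 nM in this assay, at which 1 of the 3 values shown sits.

Going by these compounds, how far the true value of compound 3 lies past this limit remains open, and a single step on a single core says nothing about whether the same change would act alike elsewhere. Also open, on these data alone, is what an amine or a methoxy group would do on this same carbon in place of the chloro group, and whether either would give a number that can be read.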